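This account rests on a few compounds, and the source may have more. Where it says the series, first, only, none or still open, it means among the compounds named here.

In a physicochemical assay for solubility (a lower number here means a less soluble compound, a higher number a more soluble compound), compound 3 `CNC(=O)c1cc(C(=O)N[C@H]2CC[C@H](O)CC2)n([C@@H](C)c2ccccc2)n1` stands at >= 180 ug/mL, which is a limit and not a number. Compound 1 `CNC(=O)c1cc(C(=O)N[C@H]2[C@@H]3C[C@@H](OC)C[C@@H]32)n([C@@H](C)c2ccccc2)n1` also gives only a limit, >= 150 ug/mL. Compound 2 `CNC(=O)c1cc(C(=O)NCCO)n([C@@H](C)c2ccccc2)n1` likewise gives only a limit, >= 139 ug/mL. With no exact number among the three, compound 3 cannot be ranked against the others.

The step followed here leads to compound 4 `CNC(=O)c1cc(C(=O)NC)n([C@@H](C)c2ccccc2)n1`, with methyl in place of 4-hydroxycyclohexyl on an amide-type nitrogen. For the measured compounds named here, all of the measured steps change the group at this same kind of place. The closest is a step that the two limits leave unreadable from compound 2 to compound 3, and the other two are a step that the two limits leave unreadable from compound 1 to compound 2 and a step that the two limits leave unreadable from compound 1 to compound 3. Going by the values given here, none of them has a readable size, but all three groups left the compounds at a limit in this assay, and no measured compound goes against this. A step beyond the scatter is therefore not expected, and another limit is the likely report. Each measured group holds an oxygen and methyl holds none, so the estimate keeps room on the low side. The expected change is an at least 1.1-fold lower number from compound 3 to compound 4 (0.05 log units; that floor lies within the scatter). For compound 4 the estimated value is 160 ug/mL, with an expected range from 95 ug/mL to 210 ug/mL.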

Compound 4, solubility: >= 88 ug/mL
Compound 4: only a limit was reported; the forecaster's own chance of this, stated with the estimate: 70%; the middle value is on the limit's open side.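

In this assay compound 4 gives >= 88 ug/mL, which is a limit and not a number. Compound 1, compound 2 and compound 3 also give only limits, so none of their steps to compound 4 can be read. The compounds shown leave open how large any difference between these groups on the amide-type nitrogen is in this assay.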